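Aryl-to-furan swap on the shared core

The source may hold more compounds than are shown below. What is called first, only, known or untested is meant among the compounds shown, and "the series" means these compounds.

Compound 1 `COc1cc(N2C(N)=C(C#N)C(c3cccc([N+](=O)[O-])c3)C3=C2CC(C)(C)CC3=O)cc(OC)c1OC`: 5% in a functional assay on Ehrlich cells (Mus musculus) for cytotoxicity, tested at 10 ug/mL; on this read-out higher numbers stand for a stronger effect at the one concentration tested and lower numbers for a weaker effect
Compound 2 `COc1cc(N2C(N)=C(C#N)C(c3ccc(C)cc3)C3=C2CC(C)(C)CC3=O)cc(OC)c1OC`: 30%
Compound 3 `COc1cc(N2C(N)=C(C#N)C(c3ccc(Cl)cc3Cl)C3=C2CC(C)(C)CC3=O)cc(OC)c1OC`: 20%

Compound 3 stands second highest of the three numbers in this assay, nearest to compound 2 and furthest from compound 1: the steps were a number 10 percentage points lower from compound 2 to compound 3 (within the scatter) and a number 15 percentage points higher from compound 1 to compound 3 (beyond the scatter). Compound 4 `COc1cc(N2C(N)=C(C#N)C(c3ccc(C)o3)C3=C2CC(C)(C)CC3=O)cc(OC)c1OC` differs from compound 3 at one place: 5-methylfuran-2-yl in place of 2,4-dichlorophenyl on a saturated ring carbon. All measured steps changed the group on this same saturated ring carbon: a number 25 percentage points higher from compound 1 to compound 2 (beyond the scatter) and a number 15 percentage points higher from compound 1 to compound 3 (beyond the scatter) were modest, while a number 10 percentage points lower from compound 2 to compound 3 (within the scatter) stayed within the scatter. None of them involved a 5-methylfuran-2-yl, so no direction can be read from them. Only a modest shift, in either direction, is therefore expected: no change at the digits printed from compound 3 to compound 4 (within the scatter). Compound 4 is estimated at 20%, within 5% to 40%.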

Compound 4, a percentage reported as activity, at one concentration (the size of the read-out at that concentration, not a potency): 21%
Compound 4: the middle estimate sits 1 percentage points below what was measured; the range from low to high includes it.
By their numbers in this assay, from the lowest: compound 1; then compounds 3, 4 and 2 (each within the scatter of the next).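

In this assay, the saturated ring carbon takes a five-membered aromatic ring with 1 hetero atom as well as a six-membered one: the 5-methylfuran-2-yl group gives a number 1 percentage points higher from compound 3 to compound 4 (within the scatter) and a number 9 percentage points lower from compound 2 to compound 4 (within the scatter) and so cannot be told apart from the 2,4-dichlorophenyl or 4-methylphenyl groups. Against the 3-nitrophenyl group it gives a number 16 percentage points higher from compound 1 to compound 4 (beyond the scatter) and compound 1 stays alone at the low end of the four. Nothing available gives a reason for this. The compounds shown leave open how a thiophene, a pyridine or a saturated cyclohexyl group on this carbon would read.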